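The compounds below may be only part of what the source reports. "The series", "measured", "known", "first", "only" and "open" are said of these compounds alone.

The measured compounds and their values in a functional assay on A549 cells (Homo sapiens), read by MTT assay, with a stated time of 72 h; a higher number here means a weaker inhibitor, a lower number a stronger inhibitor:

Compound 1 `Nc1nc2c(c(-c3ccco3)cn2[C@@H]2O[C@H](CO)[C@@H](O)[C@H]2O)c(=O)[nH]1` — in this assay compound 1 gives > 20000 nM, which is a limit of the assay, not a number.
Compound 2 `COc1nc(N)nc2c1c(-c1ccoc1)cn2[C@@H]1O[C@H](CO)[C@@H](O)[C@H]1O` — in this assay compound 2 gives > 20000 nM, again a limit rather than a number.
Compound 3 `Nc1nc2c(c(-c3ccoc3)cn2[C@@H]2O[C@H](CO)[C@@H](O)[C@H]2O)c(=O)[nH]1` — in this assay compound 3 gives > 20000 nM, once more a limit.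

All three values therefore sit at the same place: the limit of > 20000 nM in this assay, at which 3 of the 3 values shown sit. Going by the values given here, the one structural change that can be followed between measured compounds is furan-2-yl in place of furan-3-yl on an aromatic carbon, and the step it made is a step that the two limits leave unreadable from compound 3 to compound 1. Nothing can be read from that pair beyond the fact that both compounds sit at the limit.

Compound 4 `COc1nc(N)nc2c1c(-c1ccco1)cn2[C@@H]1O[C@H](CO)[C@@H](O)[C@H]1O` has not yet been measured in this assay. It differs from compound 2 by furan-2-yl in place of furan-3-yl on an aromatic carbon, and the two place lines match word for word, so this is the same change that was made from compound 3 to compound 1. The difference between the core of compound 2 and the core of compound 3 is not broken down here.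

Since both compound 3 and compound 1 sit at the limit, and compound 2 does as well, the same change on compound 2 is expected to give a step that the limit leaves unreadable from compound 2 to compound 4, which here means no readable change. Compound 4 is therefore expected to come in at about 40000 nM, within a range of 15000 nM to 200000 nM, most likely reported only as a limit.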

Compound 4, half-maximal inhibitory concentration: > 20000 nM
Compound 4 was reported as a limit; the forecaster's own chance of this, stated with the estimate: 85%; the middle value is on the limit's open side.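

In this assay compound 4 gives > 20000 nM, which is a limit of the assay and not a number. Compound 2 sits at the same limit, so no step can be read between compound 2 and compound 4. The compounds shown leave open whether furan-2-yl and furan-3-yl differ in effect on either core, because every value stands in one place: the limit of > 20000 nM in this assay, at which 4 of the 4 values shown sit.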